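The source may report more compounds than this note shows. Statements on the series, on what has been measured and on what is new or still open speak of the compounds shown alone.

Of the compounds shown here, three built on one shared core have so far been tested in a functional assay on MDA-MB-231 cells (Homo sapiens) for cytotoxicity, read by sulforhodamine B assay, with a stated time of 48 h; on this read-out higher numbers stand for weaker inhibition of growth and lower numbers for stronger inhibition of growth. Compound 1 `Nc1nc(Cl)c2ncn(Cc3ccc(CCl)cc3)c2n1` gives 34700 nM. Compound 3 `ClCc1ccc(Cn2cnc3c(Cl)nc(Cl)nc32)cc1` differs from it by chloro in place of amino on an aromatic carbon and gives 3630 nM; the change brings a 9.6-fold lower number from compound 1 to compound 3 (0.98 log units; beyond the scatter). Compound 2 `ClCc1ccccc1Cn1cnc2nc(Cl)nc(Cl)c21` gives 910 nM, the lowest of the three numbers, and its distance from compound 3 and from compound 1 lies beyond the scatter in both cases.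

Compound 4 `ClCc1ccccc1Cn1cnc2ncnc(Cl)c21` has not been measured. It differs from compound 2 in one place: hydrogen in place of chloro on an aromatic carbon. Among the measured compounds shown here, no measured pair removes a chloro from the core, so the only guide is the step from compound 1 to compound 3, where a chloro entering on an aromatic carbon of the core brought a 9.6-fold lower number from compound 1 to compound 3 (0.98 log units; beyond the scatter). Taking that step as a hint that a chloro on the core helps, its loss in compound 4 would be expected to raise the number somewhat, though hydrogen is not amino and the size is uncertain. Compound 4 is therefore expected to give about 2500 nM, with a range from 700 nM to 9000 nM. The expected step is a 2.7-fold higher number from compound 2 to compound 4 (0.44 log units; beyond the scatter).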

Compound 4, concentration for total growth inhibition: 6910 nM
Estimate against measurement, compound 4: 2.8-fold (0.44 log units) below, and the stated range covers the measured number.
By their numbers in this assay, from the lowest: compound 2; then compounds 3 and 4 (each within the scatter of the next); then compound 1.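

In this assay, taking the chloro away from its place between two ring nitrogen atoms gives a 7.6-fold higher number from compound 2 to compound 4 (0.88 log units; beyond the scatter) and so, unlike anything seen earlier, isolates what this chloro contributes when nothing takes over with a new heavy atom. The earlier change at this same spot, a 9.6-fold lower number from compound 1 to compound 3 (0.98 log units; beyond the scatter) in compounds that carry the chloromethyl group elsewhere on the benzyl ring, also favoured chloro, so in both measured pairs a lower number goes with chloro, whether the comparison is with amino or with hydrogen. Nothing measured here explains why the chloro has this effect.

Whether chloro is special at this position or other small groups would serve as well remains open, since the compounds shown include no fluoro, bromo, methyl or methoxy group there. It is also unknown whether the loss of this chloro would cost as much with the chloromethyl group placed as in compound 3, and what would happen at the other chloro of compound 4, which stays in place throughout.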